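Demethylation of compound 2: expected loss of growth inhibition

The compounds below may be only part of what the source reports. "The series", "measured", "known", "first", "only" and "open" are said of these compounds alone.

Compound 1 `O=C(Nc1cccc(-n2cc(-c3ccncc3)c(-c3ccc(Cl)c(O)c3)n2)c1)Nc1cccc(C(F)(F)F)c1`: in a functional assay on OVCAR-4 cells (Homo sapiens) for inhibition, read by sulforhodamine B assay, with a stated time of 48 h (a lower number here means a stronger inhibitor of growth, a higher number a weaker inhibitor of growth), compound 1 gives only the assay limit > 32500 nM, not a number.
Compound 2 `COc1cc(-c2nn(-c3cccc(NC(=O)Nc4cc(C(F)(F)F)cc(C(F)(F)F)c4)c3)cc2-c2ccncc2)ccc1Cl`: in this assay compound 2 gives 9640 nM.
Compound 3 `COc1cc(-c2nn(-c3cccc(NC(=O)Nc4cccc(C(F)(F)F)c4)c3)cc2-c2ccncc2)ccc1Cl`: in this assay compound 3 gives 2100 nM.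

Among the two numbers that are not limits, compound 2 stands highest, the nearest being compound 3 with a 4.6-fold lower number from compound 2 to compound 3 (0.66 log units; beyond the scatter). Compound 4 `O=C(Nc1cccc(-n2cc(-c3ccncc3)c(-c3ccc(Cl)c(O)c3)n2)c1)Nc1cc(C(F)(F)F)cc(C(F)(F)F)c1` differs from compound 2 by hydrogen in place of methyl on an oxygen on an aromatic ring; the urea end with two trifluoromethyl groups is kept.

The same change has been measured once in the opposite direction, within the pair carrying a single trifluoromethyl group: an at least 15-fold lower number from compound 1 to compound 3 (1.18 log units; beyond the scatter). That step is large and goes well beyond the scatter, though its exact size is open because compound 1 sits at the limit of > 32500 nM in this assay, at which 1 of the 3 values shown sits. Transferring it to compound 2 points to a strong rise in the number for compound 4 in this assay, in the direction of weaker growth inhibition, and the expectation is that the step of a 12-fold higher number from compound 2 to compound 4 (1.10 log units; beyond the scatter) carries compound 4 past the point where the assay reports a number. Compound 4 is therefore expected to give about 120000 nM in this assay, within a range of 30000 nM to 500000 nM, most probably returned only as a limit.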

Compound 4, concentration for total growth inhibition: 5010 nM
Estimate against measurement, compound 4: 24-fold (1.38 log units) above; the measured number lies below the stated range.
By their numbers in this assay, from the lowest: compound 3; then compounds 4 and 2 (each within the scatter of the next). At a limit, above all of these: compound 1.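

In this assay, the move from 4-chloro-3-methoxyphenyl to 4-chloro-3-hydroxyphenyl carries no fixed penalty: with the urea end bearing two trifluoromethyl groups kept, the step reads a 1.9-fold lower number from compound 2 to compound 4 (0.28 log units; within the scatter), so the hydroxy group is tolerated on this core. The same change on an aromatic ring oxygen therefore reads differently according to the urea end it is paired with: the same change on two cores in this assay, an at least 15-fold lower number (1.18 log units; beyond the scatter) from compound 1 to compound 3 and a 1.9-fold higher number (0.28 log units; within the scatter) from compound 4 to compound 2, at least 29-fold (1.47 log units) apart, beyond the scatter of two such steps. The second trifluoromethyl group shows the same dependence from the other side, since with the hydroxy group in place the step reads an at least 6.4-fold lower number from compound 1 to compound 4 (0.81 log units; beyond the scatter), the opposite direction to the step seen with the methoxy group: the same change on two cores in this assay, a 4.6-fold lower number (0.66 log units; beyond the scatter) from compound 2 to compound 3 and an at least 6.4-fold higher number (0.81 log units; beyond the scatter) from compound 4 to compound 1, at least 29-fold (1.47 log units) apart, beyond the scatter of two such steps.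

From the compounds shown here alone, compound 1 gives only a limit and not a number, so the true size of both gaps stays open: the limit of > 32500 nM in this assay, at which 1 of the 4 values shown sits. The four compounds form a single square of two changes, which leaves open whether this dependence on the urea end extends to an ethyl group on the same oxygen, or to an amine in place of the hydroxy group.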